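Hydroxy for Chloro on an Inactive Sulfonamide Series

The source may hold more compounds than are shown below. What is called first, only, known or untested is meant among the compounds shown, and "the series" means these compounds.

The shared core of compound 3 `O=S(=O)(Nc1ccc2oc(-c3ccccc3)nc2c1)c1cccc(Cl)c1` carries a 3-chlorophenyl group on the sulfonyl sulfur. In an assay on cells for inhibition of HSP60/HSP10 (Homo sapiens), with a stated time of 60 min (a higher number here means a weaker inhibitor, a lower number a stronger inhibitor), compound 3 reaches only a limit of the assay, > 100000 nM, so no number is known for it. The same holds for its two neighbours. Compound 1 `O=S(=O)(Nc1ccc2oc(-c3ccccc3)nc2c1)c1cccc(F)c1` gives in this assay a limit, > 100000 nM. Compound 2 `O=S(=O)(Nc1ccc2oc(-c3ccccc3)nc2c1)c1ccc(Cl)cc1` likewise gives a limit, > 100000 nM. The steps between them, a step that the two limits leave unreadable from compound 1 to compound 2, a step that the two limits leave unreadable from compound 1 to compound 3 and a step that the two limits leave unreadable from compound 2 to compound 3, therefore cannot be read in size or direction, as all three values sit at the limit of > 100000 nM in this assay, at which 3 of the 3 values shown sit.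

Compound 4 `O=S(=O)(Nc1ccc2oc(-c3ccccc3)nc2c1)c1cccc(O)c1` differs from compound 3 by hydroxy in place of chloro on an aromatic carbon. Among the compounds with values here, none of the measured steps tells how this exchange acts; every compound so far lies at the limit, and nothing shows a move away from it. Compound 4 is therefore expected to remain at that limit as well, with the step that the limit leaves unreadable from compound 3 to compound 4 expected to bring no readable gain. The estimate for compound 4 in this assay is 150000 nM, with a range from 40000 nM to 600000 nM.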

Compound 4, half-maximal inhibitory concentration: 76000 nM
Compound 4: middle estimate off by 2.0-fold (0.30 log units), on the high side; the range from low to high includes it.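

With 3-hydroxyphenyl on the sulfonyl sulfur, this series gives a real number rather than a limit in this assay, while the other compounds stay at that limit: the limit of > 100000 nM in this assay, at which 3 of the 4 values shown sit.

Hydroxy, which carries a hydrogen-bond donor and acceptor where the halogens count none, gives an at least 1.3-fold lower number from compound 3 to compound 4 (0.11 log units; that floor lies within the scatter) and an at least 1.3-fold lower number from compound 1 to compound 4 (0.11 log units; that floor lies within the scatter), and the change of group on the sulfur gives an at least 1.3-fold lower number from compound 2 to compound 4 (0.11 log units; that floor lies within the scatter). As far as these compounds go, these are only floors, so the true size of each step remains unknown, and the steps among compound 1, compound 2 and compound 3 still cannot be read.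

From the compounds shown here alone, it remains open whether a methoxy, an amine or a carboxylic acid in the same place would lower the number further. The compounds shown also do not tell whether 4-hydroxyphenyl would behave like 3-hydroxyphenyl.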